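Working notes: methoxy in place of nitro on compound 1

The compounds below may be only part of what the source reports. "The series", "measured", "known", "first", "only" and "open" are said of these compounds alone.

Measured so far in a functional assay on T47D cells (Homo sapiens) for cytotoxicity, read by MTT assay, with a stated time of 48 h; on this read-out lower numbers stand for stronger inhibition and higher numbers for weaker inhibition:
compound 1 `O=[N+]([O-])c1ccc(NC(=S)N/N=C\c2ccnc3ccccc23)cc1` gives 1330 nM
compound 2 `S=C(N/N=C\c1ccnc2ccccc12)Nc1cccnc1` gives 1100 nM
compound 3 `S=C(N/N=C\c1ccnc2ccccc12)Nc1ccccc1` gives 1380 nM

On these three numbers compound 1 stands second highest, and its gaps to compound 2 and to compound 3 both lie within the scatter. Compound 4 `COc1ccc(NC(=S)N/N=C\c2ccnc3ccccc23)cc1` differs from compound 1 as follows: methoxy in place of nitro on an aromatic carbon. Among the measured compounds shown here, the one step that bears on this change at the same aromatic carbon is a 1.0-fold higher number from compound 1 to compound 3 (0.02 log units; within the scatter), where removing the nitro group left the number unchanged within the scatter; the other step, a 1.3-fold higher number from compound 2 to compound 3 (0.10 log units; within the scatter), is also within the scatter. Nothing here points to a shift beyond the scatter, so the step is expected to be a 1.0-fold lower number from compound 1 to compound 4 (0.01 log units; within the scatter). Compound 4 is therefore estimated at 1300 nM, with a range from 700 nM to 2600 nM.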

Compound 4, half-maximal inhibitory concentration: 1360 nM
The estimate for compound 4 lay 1.0-fold (0.02 log units) below the measured number, within the range that was stated.
By their numbers in this assay, from the lowest: compounds 2, 1, 4 and 3 (each within the scatter of the next).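

At this aromatic carbon, para to a large group, methoxy joins nitro and hydrogen without separating from either: a 1.0-fold higher number from compound 1 to compound 4 (0.01 log units; within the scatter) and a 1.0-fold lower number from compound 3 to compound 4 (0.01 log units; within the scatter) in this assay. The 4-methoxyphenyl group in place of pyridin-3-yl on the amide-type nitrogen also stays within the scatter, with a 1.2-fold higher number from compound 2 to compound 4 (0.09 log units; within the scatter). No measurement on hand accounts for this lack of separation.

Going by these compounds, whether an amine, a carboxylic acid or a longer chain at this aromatic carbon would move the number beyond the scatter remains open.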